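Benzyl swap on the shared core: compound 2 to compound 3

The compounds below may be only part of what the source reports. "The series", "measured", "known", "first", "only" and "open" are said of these compounds alone.

For the measured compounds named here, compound 2 `O=C(O)c1ccccc1-c1ccc(CCc2ncc(Cc3ccccc3Cl)[nH]2)cc1` gives 22 nM in an in vitro functional assay on cells for agonist activity at Bombesin receptor subtype-3 (Mus musculus), read by luminescence and calcium flux (a lower number here means that less compound is needed, a higher number that more compound is needed for the effect), and sits at the upper end of the two numbers so far, though within the scatter of compound 1 `O=C(O)c1ccccc1-c1ccc(CCc2ncc(C3CCCCC3)[nH]2)cc1`, which gives 14.7 nM; the step of a 1.5-fold higher number from compound 1 to compound 2 (0.18 log units; within the scatter) confirms this. Compound 3 `Cc1cccc(Cc2cnc(CCc3ccc(-c4ccccc4C(=O)O)cc3)[nH]2)c1` differs from compound 2 by 3-methylphenyl in place of 2-chlorophenyl on a saturated chain carbon bound to an aromatic carbon. Going by the values given here, no measured step exchanges one benzyl for another; the only step, a 1.5-fold higher number from compound 1 to compound 2 (0.18 log units; within the scatter), replaced cyclohexyl with 2-chlorobenzyl and stayed within the scatter, so no step beyond the scatter is expected here either. For compound 3 the estimate is 25 nM, range 9 nM to 70 nM, an expected 1.1-fold higher number from compound 2 to compound 3 (0.06 log units; within the scatter).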

Compound 3, half-maximal effective concentration: 75 nM
Compound 3: the middle estimate sits 3.0-fold (0.48 log units) below what was measured, outside the stated range (above it).
By their numbers in this assay, from the lowest: compounds 1 and 2 (each within the scatter of the next); then compound 3.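

In this assay, for the compounds shown here, this position distinguishes one benzyl group from another: 3-methylphenyl in place of 2-chlorophenyl gives a 3.4-fold higher number from compound 2 to compound 3 (0.53 log units; beyond the scatter) and is the first step beyond the scatter. Against cyclohexyl, 3-methylbenzyl also gives a step beyond the scatter, namely a 5.1-fold higher number from compound 1 to compound 3 (0.71 log units; beyond the scatter) and unlike 2-chlorobenzyl, whose step from cyclohexyl stayed within it. Nothing available gives a reason for this difference.

Open, going by these compounds, is whether the step follows the chlorine-to-methyl exchange or the place of the group on the ring, which 3-chlorobenzyl or 2-methylbenzyl would separate. Also open, on these data alone, is how an unsubstituted benzyl or an aminobenzyl group would read here.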